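Trading ethoxycarbonyl for methoxycarbonyl in compound 1

The source may hold more compounds than are shown below. What is called first, only, known or untested is meant among the compounds shown, and "the series" means these compounds.

- compound 1 `CCOC(=O)c1sc2ccccc2c1Nc1cc(OC)c(OC)c(OC)c1` gives 3020 nM
- compound 2 `CCOC(=O)c1sc2cccc(C)c2c1Nc1cc(OC)c(OC)c(OC)c1` gives 5670 nM
- compound 3 `CCOC(=O)c1sc2cc(C)ccc2c1Nc1cc(OC)c(OC)c(OC)c1` gives 0.4 nM

These numbers come from a functional assay on Jurkat cells (Homo sapiens) for cytotoxicity, read by MTT assay, with a stated time of 72 h; on this read-out lower numbers stand for stronger inhibition and higher numbers for weaker inhibition. Compound 1 stands second highest of the three, within the scatter of compound 2 and far above compound 3.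

Compound 4 `COC(=O)c1sc2ccccc2c1Nc1cc(OC)c(OC)c(OC)c1` has not been measured yet. Its difference from compound 1 is this: hydrogen in place of methyl on a saturated chain carbon bound to an oxygen next to a carbonyl group. In words, hydrogen in place of methyl on a saturated chain carbon bound to an oxygen next to a carbonyl group, so ethoxycarbonyl becomes methoxycarbonyl.

Among the compounds with values here, only two measured steps can be consulted, and both concern methyl in place of hydrogen on an aromatic carbon, elsewhere in the molecule. One is a 1.9-fold higher number from compound 1 to compound 2 (0.27 log units; within the scatter) and the other is a 7600-fold lower number from compound 1 to compound 3 (3.88 log units; beyond the scatter). Neither tests the ethoxycarbonyl group, but together they warn that one methyl can matter enormously or not visibly. In this assay no step beyond the scatter is therefore expected, and no direction is favoured, though the uncertainty is wide.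

For compound 4 the estimated value is 2500 nM, with an expected range from 400 nM to 10000 nM.

The expected change is a 1.2-fold lower number from compound 1 to compound 4 (0.08 log units; within the scatter).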

Compound 4, half-maximal inhibitory concentration: 490 nM
The estimate for compound 4 lay 5.1-fold (0.71 log units) above the measured number; the range from low to high includes it.
By their numbers in this assay, from the lowest: compound 3; then compound 4; then compounds 1 and 2 (each within the scatter of the next).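

In this assay, shortening ethoxycarbonyl to methoxycarbonyl gives a 6.2-fold lower number from compound 1 to compound 4 (0.79 log units; beyond the scatter) and so moves the number beyond the scatter. Within the data shown here, this shows that the ethoxycarbonyl group, untouched in the earlier compounds, is a place where the loss of one methyl can be read in the assay, although this step is far smaller than a 7600-fold lower number from compound 1 to compound 3 (3.88 log units; beyond the scatter) on the aromatic carbon. No measurement shown here accounts for the step.

With only ethoxycarbonyl and methoxycarbonyl shown, it remains open whether a longer chain such as propoxycarbonyl, a carboxylic acid or an amide at this place would lower the number further or raise it. On these data alone, it is also open whether methoxycarbonyl would lower the number again when combined with the methyl of compound 3.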